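This account rests on a few compounds, and the source may have more. Where it says the series, first, only, none or still open, it means among the compounds named here.

Measured so far in an assay on COS-7 cells for inhibition of patatin-like phospholipase domain-containing protein 2 (Mus musculus), tested at 200 uM; a lower number here means less inhibition, a higher number more inhibition at the concentration tested (going by the name of the read-out):
compound 1 `CCOC(=O)c1cccc(-c2ccc(N(C)C)cc2)c1` gives 87%
compound 2 `CCOc1ccc(-c2cccc(NC(=O)N(C)C)c2)cc1` gives 68%
compound 3 `CN(C)c1ccc(-c2cccc(N)c2)cc1` gives 70%

Compound 3 stands second of the three numbers. Its nearest neighbour is compound 2, whose value lies within the scatter of that of compound 3, so the two cannot be told apart. Going by the values given here, compound 1 stands clearly above it: the step of a number 17 percentage points lower from compound 1 to compound 3 (beyond the scatter) is the only single-point change measured here, and it is modest in size.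

Compound 4 `CN(C)C(=O)Nc1cccc(-c2ccc(N(C)C)cc2)c1` is still to be measured. It differs from compound 3 in one place: dimethylcarbamoyl in place of hydrogen on a nitrogen on an aromatic ring.

Among the compounds with values here, no measured step tracks exactly this change. Within the data shown here, the one measured step, a number 17 percentage points lower from compound 1 to compound 3 (beyond the scatter), concerns another group on another ring and says nothing direct about adding a dimethylcarbamoyl. What does bear on it is the pair of compound 2 and compound 3: compound 2 already carries the (dimethylcarbamoyl)amino group, on a core that otherwise differs in one other group, and its value sits within the scatter of that of compound 3. Taken together, these numbers suggest that the change from compound 3 to compound 4 moves the inhibition little, if at all.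

Compound 4 is therefore expected to give about 72%, with a range from 55% to 88%; the expected step of a number 2 percentage points higher from compound 3 to compound 4 (within the scatter) lies within the scatter.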

Compound 4, a percentage reported as inhibition, at one concentration (the size of the read-out at that concentration, not a potency): 98%
Beside the measured number, compound 4's estimate is 26 percentage points below it; the whole stated range lies below it.
By their numbers in this assay, from the lowest: compounds 2 and 3 (each within the scatter of the next); then compound 1; then compound 4.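

Going by these compounds alone, putting dimethylcarbamoyl on the nitrogen of compound 3 gives in this assay a number 28 percentage points higher from compound 3 to compound 4 (beyond the scatter), so this nitrogen on an aromatic ring responds to the change, which the earlier compounds could not show directly. The (dimethylcarbamoyl)amino group does not set the number alone: with that group held fixed, dimethylamino in place of ethoxy gives a number 30 percentage points higher from compound 2 to compound 4 (beyond the scatter), so the outcome also depends on the group at the other end of the molecule. At the aromatic carbon that carries the group, (dimethylcarbamoyl)amino in place of ethoxycarbonyl gives a number 11 percentage points higher from compound 1 to compound 4 (beyond the scatter), which places compound 4 clearly above compound 1 as well as compound 3 and makes it the highest of the four in this assay.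

Nothing shown here accounts for these steps. The compounds shown leave open whether an acetyl group or a methylcarbamoyl group on the same nitrogen would do the same, and whether a longer chain in place of the methyl groups of the dimethylcarbamoyl would keep the number this high.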